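A few compounds are considered here, and "the series" means these few. Any claim that something is new, unique, unknown or untested is made for them only; others in the source may bear on it.

Compound 1 `COc1cc(Oc2cccc(Nc3ccccc3)c2)cc(OC)c1CNCCNC(C)=O` and compound 2 `COc1ccc(CCCNCc2c(OC)cc(Oc3cccc(Nc4ccccc4)c3)cc2OC)cc1` share one core and differ on a saturated chain carbon two bonds along the chain from an amine nitrogen. In a functional assay on HCT-116 cells (Homo sapiens) for inhibition, read by MTT assay, with a stated time of 72 h (on this read-out lower numbers stand for stronger inhibition and higher numbers for weaker inhibition), compound 1 gives 18200 nM, and compound 2 gives 2850 nM, the lower of the two numbers a 6.4-fold lower number from compound 1 to compound 2 (0.81 log units; beyond the scatter). Compound 3 `COc1cc(Oc2cccc(Nc3ccccc3)c2)cc(OC)c1CNCc1ccc(Br)cc1` is not yet measured; it carries 4-bromophenyl in place of 2-(4-methoxyphenyl)ethyl on a saturated chain carbon bound to an amine nitrogen. Among the measured compounds shown here, only that one step, from compound 1 to compound 2, bears on this change, and it swapped a different part of the side chain, so it guides the expectation loosely. Compound 3 is expected to change little, a 1.1-fold lower number from compound 2 to compound 3 (0.06 log units; within the scatter), giving an estimated 2500 nM between 800 nM and 8000 nM.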

Compound 3, half-maximal inhibitory concentration: 6230 nM
For compound 3 the middle estimate is 2.5-fold (0.40 log units) below the measured one; measured number inside the range.
By their numbers in this assay, from the lowest: compound 2; then compound 3; then compound 1.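

In this assay the 4-bromobenzyl side chain gives a 2.2-fold higher number from compound 2 to compound 3 (0.34 log units; beyond the scatter) and still a 2.9-fold lower number from compound 1 to compound 3 (0.47 log units; beyond the scatter). Both side chains ending in a ring, 3-(4-methoxyphenyl)propyl and 4-bromobenzyl, thus read lower than the acetamido chain of compound 1, yet the two are not interchangeable, with compound 2 keeping the lowest number. Nothing measured here explains this order. Compound 2 and compound 3 differ in both chain length and ring substituent, and these two changes remain unseparated. A 4-methoxybenzyl or 3-(4-bromophenyl)propyl group would tell them apart.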